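Working notes: 4-fluorobenzyl to 3-chloro-5-fluorobenzyl

This account rests on a few compounds, and the source may have more. Where it says the series, first, only, none or still open, it means among the compounds named here.

Of the compounds shown here, three sharing one core have numbers so far. In an ADME assay on A549 cells (Homo sapiens) for cytotoxicity, read by resazurin assay, with a stated time of 48 h (a higher number here means that more compound is tolerated, a lower number that less compound is tolerated), compound 1 `CC(C)CNc1ccc(NC(=O)c2cc(Cl)ccc2O)c(Cl)c1` gives 60000 nM, compound 2 `O=C(Nc1ccc(NCC2CC2)cc1Cl)c1cc(Cl)ccc1O` gives 14400 nM and compound 3 `O=C(Nc1ccc(NCc2ccc(F)cc2)cc1Cl)c1cc(Cl)ccc1O` gives 54400 nM. Compound 3 stands level with compound 1, as shown by a 1.1-fold lower number from compound 1 to compound 3 (0.04 log units; within the scatter). It stands clear of compound 2, as shown by a 3.8-fold higher number from compound 2 to compound 3 (0.58 log units; beyond the scatter).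

The next structure, compound 4 `O=C(Nc1ccc(NCc2cc(F)cc(Cl)c2)cc1Cl)c1cc(Cl)ccc1O`, carries 3-chloro-5-fluorophenyl in place of 4-fluorophenyl on a saturated chain carbon bound to a nitrogen on an aromatic ring. All three measured steps fall at this same place, but each exchanges one whole group for another. None of them changes the substituents on a phenyl ring, so they bear on the new step only indirectly. The largest of them is a 4.2-fold lower number from compound 1 to compound 2 (0.62 log units; beyond the scatter), and it is modest. The two aryl-bearing comparisons give no sign of a large move, since isopropyl to 4-fluorophenyl produced only a 1.1-fold lower number from compound 1 to compound 3 (0.04 log units; within the scatter).

In this assay, a small drift downward is expected, with no step beyond the scatter. The estimated step is a 1.4-fold lower number from compound 3 to compound 4 (0.13 log units; within the scatter). For compound 4 the expected value is 40000 nM, within an estimated range of 16000 nM to 85000 nM.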

Compound 4, half-maximal cytotoxic concentration: 11100 nM
Beside the measured number, compound 4's estimate is 3.6-fold (0.56 log units) above it; measured number below the stated range.
By their numbers in this assay, from the lowest: compounds 4 and 2 (each within the scatter of the next); then compounds 3 and 1 (each within the scatter of the next).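

In this assay, the substituents on the phenyl ring at this position matter: a 4.9-fold lower number from compound 3 to compound 4 (0.69 log units; beyond the scatter) shows that a change within the ring can shift the number by a modest step. The earlier compounds shown here showed only exchanges of one whole group for another, and the single aryl case, compound 3, could not be told from the isopropyl compound 1. With 3-chloro-5-fluorophenyl in place, that level standing is gone, as a 5.4-fold lower number from compound 1 to compound 4 (0.73 log units; beyond the scatter) lies beyond the scatter, whereas a 1.3-fold lower number from compound 2 to compound 4 (0.11 log units; within the scatter) lies within it, so an aryl group here does not by itself keep the number at the level of compound 1, and no measurement shown gives a reason for the shift.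

The compounds shown leave open whether the step follows the added chlorine or the changed place of the fluorine, and a plain benzyl group or a benzyl group carrying a single chlorine would help separate these. They also leave open how this position responds to a group of another kind, such as a benzyl group carrying an amine or a carboxylic acid.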